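This account rests on a few compounds, and the source may have more. Where it says the series, first, only, none or still open, it means among the compounds named here.

Measured so far in a functional assay on NIH3T3 cells (Mus musculus) for inhibition, read by neutral red uptake, with a stated time of 24 h; on this read-out higher numbers stand for an effect only at larger amounts of compound and lower numbers for an effect already at smaller amounts:
- compound 1 `CCN(CC)CCCC(C)NC(=O)OC1=C(c2cccc3ncccc23)Oc2cc3ccccc3cc2-n2cccc21` gives 6000 nM
- compound 2 `CC(C)(C)OC(=O)N1CCC(C(=O)OC2=C(c3cccc4ncccc34)Oc3cc4ccccc4cc3-n3cccc32)CC1` gives 6000 nM

Compound 2 stands level with compound 1 at the digits shown, so the two are within the scatter of each other and neither leads the series. The next compound to be read is compound 3 `O=C(OC1=C(c2cccc3ncccc23)Oc2cc3ccccc3cc2-n2cccc21)C1CCNCC1`. It arises from compound 2 by one change, (hydrogen in place of tert-butoxycarbonyl on an amine nitrogen in a ring), with hydrogen in place of tert-butoxycarbonyl on an amine nitrogen in a ring. Within the data shown here, no measured step in this assay shows what such a change does. Among the measured compounds shown here, the only guide is that compound 1 at 6000 nM and compound 2 at 6000 nM stand level. No step beyond the scatter is therefore expected, and any drift is expected only slightly towards lower numbers. The estimated step is a 1.2-fold lower number from compound 2 to compound 3 (0.08 log units; within the scatter). Compound 3 is expected at 5000 nM, within an estimated range of 2000 nM to 13000 nM.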

Compound 3, half-maximal effective concentration: 600 nM
The estimate for compound 3 lay 8.3-fold (0.92 log units) above the measured number, and the stated range ends above it.
By their numbers in this assay, from the lowest: compound 3; then compounds 1 and 2 (each within the scatter of the next).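

In this assay, among these compounds, the amine nitrogen of the six-membered non-aromatic ring is the first place where a single change gives a step beyond the scatter: hydrogen in place of tert-butoxycarbonyl there gives a 10-fold lower number from compound 2 to compound 3 (1.00 log units; beyond the scatter). Piperidin-4-yl in place of (4-(diethylamino)-1-methylbutyl)amino on the carbonyl carbon gives a 10-fold lower number from compound 1 to compound 3 (1.00 log units; beyond the scatter), a step of the same printed size. No measurement at hand gives a reason for either step.

The compounds shown leave open whether a methyl or acetyl group on that ring nitrogen would stay with compound 3 or return to the level of compound 2. They also leave open how an open-chain primary amine in place of piperidin-4-yl on the carbonyl carbon would read.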